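Glycosyl triazole indoles: oxime to fluoro-oxindolylidene switch

The compounds below may be only part of what the source reports. "The series", "measured", "known", "first", "only" and "open" are said of these compounds alone.

Measured so far in a functional assay on A549 cells (Homo sapiens) for cytotoxicity, read by sulforhodamine B assay, with a stated time of 48 h; on this read-out higher numbers stand for weaker inhibition and lower numbers for stronger inhibition:
- compound 1, `COc1ccc2c(c1)c(/C=N/O)cn2Cc1cn([C@@H]2O[C@H](COC(C)=O)[C@@H](OC(C)=O)[C@H](OC(C)=O)[C@H]2OC(C)=O)nn1`: > 200000 nM
- compound 2, `CC(=O)OC[C@H]1O[C@@H](n2cc(Cn3cc([N+](=O)[O-])c4ccccc43)nn2)[C@H](OC(C)=O)[C@@H](OC(C)=O)[C@@H]1OC(C)=O`: 93200 nM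
- compound 3, `CC(=O)OC[C@H]1O[C@@H](n2cc(Cn3cc(/C=C4/C(=O)Nc5ccccc54)c4ccccc43)nn2)[C@H](OC(C)=O)[C@@H](OC(C)=O)[C@@H]1OC(C)=O`: > 200000 nM

The value of compound 1 in this assay is a limit, not a number. Compound 3 likewise sits at a limit in this assay. Going by the values given here, compound 2 gives a number, 93200 nM, and it is the only number in the set; the limit of > 200000 nM in this assay, at which 2 of the 3 values shown sit, marks where the other two stand. Among the compounds with values here, the one step between compounds that differ in a single place is an at least 2.1-fold higher number from compound 2 to compound 3 (0.33 log units; beyond the scatter), where an oxindolylidene group replaces a nitro group on an aromatic carbon of the shared core.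

Compound 4, `COc1ccc2c(c1)c(/C=C1/C(=O)Nc3ccc(F)cc31)cn2Cc1cn([C@@H]2O[C@H](COC(C)=O)[C@@H](OC(C)=O)[C@H](OC(C)=O)[C@H]2OC(C)=O)nn1`, is not yet measured. It differs from compound 1 by a group of 12 heavy atoms (9 carbon, 1 nitrogen, 1 oxygen, 1 fluorine; one five-membered non-aromatic ring with 1 hetero atom, one six-membered aromatic ring of carbon only) in place of a group of 3 heavy atoms (1 carbon, 1 nitrogen, 1 oxygen; no ring), on an aromatic carbon. This change is of the same kind as the step from compound 2 to compound 3, which moved the number to the limit, and compound 1 already stands at that limit. Compound 4 is therefore expected to remain at or beyond the limit, with a step that the limit leaves unreadable from compound 1 to compound 4 meaning no step beyond the scatter. The estimate for compound 4 is 250000 nM, within 100000 nM to 700000 nM.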

Compound 4, half-maximal inhibitory concentration: > 200000 nM
Compound 4: a limit, no number; the forecaster's own chance of this, stated with the estimate: 75%; the middle value lies beyond the limit too.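

Going by these compounds alone, compound 1 and compound 4 both stand at a limit, so no step between them can be read: the limit of > 200000 nM in this assay, at which 3 of the 4 values shown sit. As far as these compounds go, whether the group of 12 heavy atoms changes cytotoxicity on the core of compound 1 at all, and how far either compound lies beyond the limit, stays open.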